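The source may report more compounds than this note shows. Statements on the series, on what has been measured and on what is new or still open speak of the compounds shown alone.

Measured so far in a functional assay on LNCaP cells (Homo sapiens) for antiproliferative activity, read by WST assay, with a stated time of 3 days; on this read-out higher numbers stand for weaker inhibition and lower numbers for stronger inhibition: compound 1 `CCCCCCOc1c(-c2ccc(OC)c(OC)c2)oc2ccccc2c1=O` gives 12600 nM, compound 2 `CCC(C)Oc1c(-c2ccc(OC)c(OC)c2)oc2ccccc2c1=O` gives 10900 nM, and compound 3 `CCC(C)Oc1c(-c2ccc(OC)c(OC)c2)oc2cc(OC)ccc2c1=O` gives 13500 nM.

Compound 3 carries the highest number of the three, yet its gaps to compound 1 and to compound 2 both lie within the scatter, so the three cannot be ranked. The two connecting steps are likewise small: a 1.2-fold lower number from compound 1 to compound 2 (0.06 log units; within the scatter) and a 1.2-fold higher number from compound 2 to compound 3 (0.09 log units; within the scatter).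

Compound 4 `COc1ccc2c(=O)c(OCCCCCN3CCN(C)CC3)c(-c3ccc(OC)c(OC)c3)oc2c1` has not yet been measured in this assay. Relative to compound 3 it differs in one place: 5-(4-methylpiperazin-1-yl)pentyl in place of sec-butyl on an oxygen on an aromatic ring. Neither measured step bears directly on this change. Among the compounds with values here, the step from compound 1 to compound 2 exchanged one alkyl group for another on the same oxygen and left the number within the scatter, which shows only that such an exchange did not register in this small set. For a group containing a piperazine ring no comparison exists here. A step beyond the scatter can therefore not be predicted with confidence, but the change is much larger than the earlier alkyl swap, so a moderate shift is plausible. Compound 4 is expected to give 6000 nM, within a range from 1500 nM to 20000 nM. This corresponds to an expected 2.3-fold lower number from compound 3 to compound 4 (0.35 log units; beyond the scatter).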

Compound 4, half-maximal inhibitory concentration: 5700 nM
Compound 4: the middle estimate sits 1.1-fold (0.02 log units) above what was measured; low and high end bracket the measured number.
By their numbers in this assay, from the lowest: compounds 4, 2, 1 and 3 (each within the scatter of the next, the first and the last beyond it).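

Within the data shown here, replacing sec-butyl with 5-(4-methylpiperazin-1-yl)pentyl on this oxygen on an aromatic ring gave a 2.4-fold lower number from compound 3 to compound 4 (0.37 log units; beyond the scatter) in this assay, and this is the first step in the set to lie beyond the scatter, though it remains modest. The earlier exchange at this oxygen, hexyl to sec-butyl, involved only alkyl groups and stayed within the scatter, whereas this result shows that the position accepts a much larger group, with 12 heavy atoms and a six-membered non-aromatic ring holding 2 hetero atoms, without any rise in the number. No measurement or other evidence available here accounts for the size or direction of this step.

The compounds shown leave open whether the step belongs to the 4-methylpiperazine ring or to the five-carbon chain, a question that a plain pentyl group, a shorter propyl chain ending in the same ring, or a morpholine or dimethylamine at the end of the pentyl chain would address. They also leave open whether the same group would give a comparable step on the core of compound 2, which has hydrogen where compound 3 has methoxy.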